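Adding a (3-fluorobenzyl)oxy group to a shared core

The compounds below may be only part of what the source reports. "The series", "measured", "known", "first", "only" and "open" are said of these compounds alone.

Three compounds have been measured in a functional assay on A549 cells (Homo sapiens) for antiproliferative activity, read by MTT assay, with a stated time of 72 h; on this read-out higher numbers stand for weaker inhibition and lower numbers for stronger inhibition:
Compound 1 `COc1cc2ncnc(Nc3ccc(F)c(Cl)c3)c2cc1OCCCCC(=O)Nc1ccc(S(N)(=O)=O)cc1` gives 15500 nM.
Compound 2 `COc1cc2ncnc(Nc3cccc(Cl)c3)c2cc1OCCCCC(=O)Nc1ccc(S(N)(=O)=O)cc1` gives 11200 nM.
Compound 3 `COc1cc2ncnc(Nc3cccc(Cl)c3F)c2cc1OCCCCC(=O)Nc1ccc(S(N)(=O)=O)cc1` gives 10500 nM.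

Compound 2 holds the second highest of these three numbers, yet its steps to the others are small: a 1.4-fold lower number from compound 1 to compound 2 (0.14 log units; within the scatter) and a 1.1-fold lower number from compound 2 to compound 3 (0.03 log units; within the scatter), both within the scatter. Compound 4 `COc1cc2ncnc(Nc3ccc(OCc4cccc(F)c4)c(Cl)c3)c2cc1OCCCCC(=O)Nc1ccc(S(N)(=O)=O)cc1` differs from compound 2 by (3-fluorobenzyl)oxy in place of hydrogen on an aromatic carbon. Within the data shown here, none of the measured steps adds such a group; each only exchanges fluoro for hydrogen on the aniline ring, and even the combined change, a 1.5-fold lower number from compound 1 to compound 3 (0.17 log units; within the scatter), stays within the scatter. Those steps therefore give little guidance for a far larger addition, and no step beyond the scatter is expected in either direction, with wide uncertainty. Compound 4 is expected to give 8000 nM, between 2000 nM and 30000 nM. The expected step is thus a 1.4-fold lower number from compound 2 to compound 4 (0.15 log units; within the scatter).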

Compound 4, half-maximal inhibitory concentration: 7860 nM
Beside the measured number, compound 4's estimate is 1.0-fold (0.01 log units) above it, and the stated range covers the measured number.
By their numbers in this assay, from the lowest: compounds 4, 3, 2 and 1 (each within the scatter of the next).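

On this aromatic carbon, ortho to a chloro group, a group as large as (3-fluorobenzyl)oxy, with 9 heavy atoms and its own aromatic ring, gives a 1.4-fold lower number from compound 2 to compound 4 (0.15 log units; within the scatter) and so does not shift the number beyond the scatter. Putting it in place of fluoro gives a 2.0-fold lower number from compound 1 to compound 4 (0.29 log units; within the scatter) and also stays within the scatter. The position therefore carries this much larger group with no change that can be read, as was already true of the small fluoro exchanges.

No supporting measurement offers an explanation for this result. On these data alone, whether an amine or a carboxylic acid at this carbon would move the number beyond the scatter remains open.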